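Chain extension on the shared core: compound 4

A few compounds are considered here, and "the series" means these few. Any claim that something is new, unique, unknown or untested is made for them only; others in the source may bear on it.

The series shares the core of compound 1 `CCCn1c(Cc2cc(OC)c(OC)c(OC)c2)nc2c(N)ncnc21`. Among the measured compounds shown here, in a functional assay on MCF7 cells (Homo sapiens) for antiproliferative activity (on this read-out higher numbers stand for weaker inhibition and lower numbers for stronger inhibition), compound 1 gives 46800 nM, the highest of the three numbers measured so far; compound 2 `CCCn1c(Cc2cc(OC)c(OC)c(OC)c2)nc2c(N)nc(F)nc21` gives 25100 nM and compound 3 `CCCCn1c(Cc2cc(OC)c(OC)c(OC)c2)nc2c(N)nc(F)nc21` gives 24000 nM. The step of a 1.9-fold lower number from compound 1 to compound 2 (0.27 log units; within the scatter) and the step of a 1.0-fold lower number from compound 2 to compound 3 (0.02 log units; within the scatter) both lie within the scatter, so the three measured compounds cannot be ordered against each other.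

Compound 4 `C=CCCn1c(Cc2cc(OC)c(OC)c(OC)c2)nc2c(N)ncnc21` differs from compound 1 by vinyl in place of methyl on a saturated chain carbon, two bonds along the chain from an aromatic nitrogen. For the measured compounds named here, the one measured step on the chain, a 1.0-fold lower number from compound 2 to compound 3 (0.02 log units; within the scatter), lengthens propyl to butyl and leaves the number unchanged within the scatter; the change to compound 4 also lengthens the chain, here ending in a double bond, and no measured pair shows what that double bond does. The expectation is therefore no step beyond the scatter. For compound 4 the estimated step is a 1.2-fold lower number from compound 1 to compound 4 (0.07 log units; within the scatter), and the expected value is 40000 nM with a range of 15000 nM to 110000 nM.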

Compound 4, half-maximal inhibitory concentration: 40700 nM
Compound 4: the middle estimate sits 1.0-fold (0.01 log units) below what was measured, within the range that was stated.
By their numbers in this assay, from the lowest: compounds 3, 2, 4 and 1 (each within the scatter of the next).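

In this assay the step of a 1.1-fold lower number from compound 1 to compound 4 (0.06 log units; within the scatter) lies within the scatter, so replacing methyl with vinyl at this place, on a saturated chain carbon, two bonds along the chain from an aromatic nitrogen, gives no readable change. The earlier chain step concerned a saturated chain on the fluoro compounds, whereas propyl to but-3-en-1-yl extends that finding to a chain ending in a double bond and to the core without fluoro. Nothing measured on these compounds gives a reason for this result.

The compounds shown do not separate the effect of the double bond from that of the added length, as no pair differs by the double bond alone. Going by these compounds, it remains open whether a terminal amine, a carboxylic acid or a much longer chain at this place would give a step beyond the scatter.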